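The source may report more compounds than this note shows. Statements on the series, on what has been measured and on what is new or still open speak of the compounds shown alone.

Series notes. Compound 1 `Cc1c(OCCCCOc2ccc(C(=O)O)cc2)ccc(C(=O)CC2CCCC2)c1O` and compound 2 `Cc1c(OCCCCOc2ccc(C(=O)O)cc2F)ccc(C(=O)CC2CCCC2)c1O` share one core; compound 3 `Cc1c(OCCCCOc2ccc(F)c(C(=O)O)c2)ccc(C(=O)CC2CCCC2)c1C` and compound 4 `Cc1c(OCCCCOc2cccc(C(=O)O)c2)ccc(C(=O)CC2CCCC2)c1C` share another, and the difference between the two cores is not broken down here. In an assay on HEK293 cells for positive allosteric modulation of metabotropic glutamate receptor 2 (Rattus norvegicus), read by thallium flux, with a stated time of 2.5 min (a higher number here means that more compound is needed for the effect, a lower number that less compound is needed), compound 2 gives 639 nM and compound 1 gives 824 nM; the change hydrogen in place of fluoro on an aromatic carbon gave a 1.3-fold higher number from compound 2 to compound 1 (0.11 log units; within the scatter). In this assay compound 3 gives "not determined" (no result reported), so no number stands for it. The change from compound 3 to compound 4 is hydrogen in place of fluoro on an aromatic carbon, the same kind of change as from compound 2 to compound 1, though there the hydrogen entered ortho to a large group and meta to a carboxy group, while here it enters ortho to a carboxy group and para to a large group. The step from compound 3 to compound 4 in this assay is expected to be small, as the earlier one was, but with no value for compound 3 it cannot be set as a number beside it. The expectation for compound 4 rests on compound 1 with 824 nM and compound 2 with 639 nM, read across a core for which no value is given. In this assay compound 4 is expected to give 1500 nM, estimated within 300 nM to 8000 nM.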

Compound 4, half-maximal effective concentration: "not active" (no number reported)
For compound 4 the study gives words and no number; no gap can be computed for the estimate.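

In this assay compound 3 carries no number and compound 4 only the words "not active", so no step can be read between them. From the compounds shown here alone, whether fluoro matters on this core stays open, and nothing given here bears on the result.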